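The source may hold more compounds than are shown below. What is called first, only, known or untested is meant among the compounds shown, and "the series" means these compounds.

Compound 1 `COc1ccccc1-c1ccc2ncn(-c3cc(OC)c(OC)c(OC)c3)c2c1` belongs to a small set of three compounds that share one core and differ only in the aryl group attached to it. In a functional assay on A549 cells (Homo sapiens) for antiproliferative activity, read by MTT assay, with a stated time of 72 h (on this read-out lower numbers stand for stronger inhibition and higher numbers for weaker inhibition), compound 1 gives 4320 nM, the second highest number of the three, so it is among the weaker inhibitors shown. Its nearest neighbour is compound 3 `COc1cc(-n2cnc3ccc(-c4cccc([N+](=O)[O-])c4)cc32)cc(OC)c1OC`, which in this assay gives 5410 nM; the step of a 1.3-fold higher number from compound 1 to compound 3 (0.10 log units; within the scatter) lies within the scatter. Far from both stands compound 2 `COc1ccc(-c2ccc3ncn(-c4cc(OC)c(OC)c(OC)c4)c3c2)cc1O`, which in this assay gives 200 nM; the step of a 22-fold lower number from compound 1 to compound 2 (1.33 log units; beyond the scatter) is large, as is the step of a 27-fold higher number from compound 2 to compound 3 (1.43 log units; beyond the scatter).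

Compound 4 `COc1cc(-n2cnc3ccc(-c4ccc(Cl)cc4)cc32)cc(OC)c1OC` has not yet been measured. The change from compound 1 is 4-chlorophenyl in place of 2-methoxyphenyl on an aromatic carbon. Among the compounds with values here, two measured steps bear on it. Swapping the 2-methoxyphenyl for a 3-nitrophenyl, which also carries no hydroxyl, moved the number only within the scatter, as seen in a 1.3-fold higher number from compound 1 to compound 3 (0.10 log units; within the scatter). The one large gain came with a 3-hydroxy-4-methoxyphenyl in a 22-fold lower number from compound 1 to compound 2 (1.33 log units; beyond the scatter), and compound 4 gains no such group. Compound 4 is therefore expected to sit close to compound 1, with a step of a 1.1-fold lower number from compound 1 to compound 4 (0.03 log units; within the scatter) that stays within the scatter. The estimate for compound 4 in this assay is 4000 nM, with a range from 1500 nM to 12000 nM.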

Compound 4, half-maximal inhibitory concentration: > 10000 nM
Compound 4 ended at the assay's limit; the forecaster's own chance of this, stated with the estimate: 5%; at least 2.5-fold (0.39 log units) between middle value and limit.
By their numbers in this assay, from the lowest: compound 2; then compounds 1 and 3 (each within the scatter of the next). At a limit, above all of these: compound 4.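

Compound 4 ended at a limit of this assay, not at a number: the limit of > 10000 nM in this assay, at which 1 of the 4 values shown sits. Even so, the position is not indifferent to a swap between aryl groups that carry no hydroxyl, since the step of an at least 2.3-fold higher number from compound 1 to compound 4 (0.36 log units; beyond the scatter) lies beyond the scatter, which the earlier step of a 1.3-fold higher number from compound 1 to compound 3 (0.10 log units; within the scatter) did not. The floor of the step of an at least 1.8-fold higher number from compound 3 to compound 4 (0.26 log units; that floor lies within the scatter) lies within the scatter, so 4-chlorophenyl cannot be told apart from 3-nitrophenyl, while the step of an at least 50-fold higher number from compound 2 to compound 4 (1.69 log units; beyond the scatter) is large, leaving compound 2, with its 3-hydroxy-4-methoxyphenyl, as the only one of the four with a number far lower than the rest.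

Going by these compounds, how far compound 4 really lies past the limit stays open, and so does whether the loss follows the chlorine itself or the place of the substituent on the ring. On these data alone, it is also open whether a 4-fluorophenyl or 4-methoxyphenyl would group with compound 1 or with compound 4, and whether an amine in place of the hydroxyl of compound 2 would keep its low number.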